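The source may hold more compounds than are shown below. What is called first, only, known or untested is meant among the compounds shown, and "the series" means these compounds.

Measured compounds: compound 1 `CCN1C(=O)C(=O)c2cc(-c3ccc(OC)cc3)ccc21` with 2200 nM; compound 2 `COc1ccc(CN2C(=O)C(=O)c3cc(-c4ccc(OC)c(OC)c4)ccc32)cc1` with 260 nM.

In a functional assay on K562 cells (Homo sapiens) for antiproliferative activity, read by MTT assay, with a stated time of 48 h (a lower number here means a stronger inhibitor, a higher number a weaker inhibitor), compound 2 stands at the lower of the two numbers, with compound 1 the higher number, a gap beyond the scatter. Compound 3 `COc1ccc(CN2C(=O)C(=O)c3cc(-c4ccc(C(F)(F)F)cc4)ccc32)cc1` differs from compound 2 in one place:

4-(trifluoromethyl)phenyl in place of 3,4-dimethoxyphenyl on an aromatic carbon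

Among the compounds with values here, no step between measured compounds has been recorded, so the effect of this change is untested. The writer expects compound 3 to fall somewhat behind compound 2, a step of a 2.3-fold higher number from compound 2 to compound 3 (0.36 log units; beyond the scatter) that may reach beyond the scatter. The estimate for compound 3 is 600 nM, within a range from 150 nM to 2500 nM.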

Compound 3, half-maximal inhibitory concentration: 350 nM
Compound 3: the middle estimate sits 1.7-fold (0.23 log units) above what was measured; low and high end bracket the measured number.
By their numbers in this assay, from the lowest: compounds 2 and 3 (each within the scatter of the next); then compound 1.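

In this assay, 4-(trifluoromethyl)phenyl in place of 3,4-dimethoxyphenyl on an aromatic carbon gives a 1.3-fold higher number from compound 2 to compound 3 (0.13 log units; within the scatter) within the scatter, so the two compounds cannot be told apart. This position therefore accepts a group with no hydrogen-bond acceptors as well as one with two of them, at the same level of activity. No measurement at hand bears on the reason for this. Still open, as far as these compounds go, is how a phenyl ring carrying an amine or a carboxylic acid would read here. Compound 1 differs from compound 2 in more than one place, so its gap cannot yet be assigned to either.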